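Cytotoxicity limits in a hydrazone series, towards compound 4

The source may report more compounds than this note shows. Statements on the series, on what has been measured and on what is new or still open speak of the compounds shown alone.

Measured so far:
compound 1 `Cc1ccc(S(=O)(=O)N2CC3(C[C@H]2C(=O)N/N=C/c2cccc([N+](=O)[O-])c2)SCCS3)cc1` — > 395000 nM
compound 2 `C/C(=N\NC(=O)Cn1c(=O)c(C)nc2ccccc21)c1ccccc1Cl` — > 543000 nM
compound 3 `COc1ccc(/C=N/NC(=O)Cn2c(=O)c(C)nc3ccccc32)cc1OC` — > 526000 nM

In a functional assay on C8166 cells (Homo sapiens) for cytotoxicity, read by MTT assay, with a stated time of 72 h (a higher number here means that more compound is tolerated, a lower number that less compound is tolerated), compound 1 gives > 395000 nM, which is a limit of the assay and not a number. Compound 2 gives > 543000 nM, also a limit. Compound 3 gives > 526000 nM, again a limit. For the measured compounds named here, compound 1 therefore stands at one of three limits (the limit of > 395000 nM in this assay, at which 1 of the 3 values shown sits), the other two values sitting at the limit of > 526000 nM in this assay, at which 1 of the 3 values shown sits, and (the limit of > 543000 nM in this assay, at which 1 of the 3 values shown sits); no measured compound has a numerical reading, and no two of them differ in a single place, so no measured step is available.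

Compound 4 `Cc1ccc(S(=O)(=O)N2CC3(C[C@H]2C(=O)N/N=C/c2ccccc2Cl)SCCS3)cc1` differs from compound 1 by 2-chlorophenyl in place of 3-nitrophenyl on a carbon with a double bond to nitrogen. With every measured compound at a limit, no step beyond the usual scatter is expected in this assay in either direction. Compound 4 is expected to tolerate about 400000 nM, in a range from 150000 nM to 900000 nM, and most likely to be reported only as a limit again. The expected step that the limit leaves unreadable from compound 1 to compound 4 is estimated to be no more than the scatter.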

Compound 4, half-maximal cytotoxic concentration: > 404000 nM
Compound 4: a limit, no number; the forecaster's own chance of this, stated with the estimate: 80%; at least 1.0-fold (0.00 log units) between middle value and limit.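

Compound 1 and compound 4 both stand at limits in this assay, not at numbers, so the step for 2-chlorophenyl in place of 3-nitrophenyl cannot be read. The compounds shown leave open the concentration at which any of them reaches the half-maximal cytotoxic effect, and whether this exchange alters tolerance at all.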